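Moving the Chlorine: From Compound 1 to Compound 4

This account rests on a few compounds, and the source may have more. Where it says the series, first, only, none or still open, it means among the compounds named here.

Compound 1, `Oc1ccc(-c2cc(-c3ccc(Cl)cc3)nc(-c3cccnc3)c2)cc1`: 29300 nM
Compound 2, `Oc1ccc(-c2cc(-c3ccc(Cl)cc3)nc(-c3cccs3)c2)cc1`: 6450 nM
Compound 3, `Oc1cccc(-c2cc(-c3ccc(Cl)cc3)nc(-c3cccnc3)c2)c1`: 18100 nM

All three were tested in a functional assay on T47D cells (Homo sapiens) for cytotoxicity, read by CCK-8 assay and cell counting, with a stated time of 2 days; on this read-out lower numbers stand for stronger inhibition and higher numbers for weaker inhibition. Compound 1 gives the highest number of the three; compound 3 is nearest, and the step of a 1.6-fold lower number from compound 1 to compound 3 (0.21 log units; within the scatter) lies within the scatter, while the step of a 4.5-fold lower number from compound 1 to compound 2 (0.66 log units; beyond the scatter) is a modest improvement.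

Compound 4, `Oc1ccc(-c2cc(-c3cccnc3)nc(-c3cccc(Cl)c3)c2)cc1`, differs from compound 1 by 3-chlorophenyl in place of 4-chlorophenyl on an aromatic carbon. Going by the values given here, no measured step alters this chlorophenyl group, so there is no direct guide. The closest parallel is a 1.6-fold lower number from compound 1 to compound 3 (0.21 log units; within the scatter), where 3-hydroxyphenyl replaced 4-hydroxyphenyl without a change beyond the scatter. Compound 4 is therefore expected to stay close to compound 1 in this assay, a step of a 1.2-fold lower number from compound 1 to compound 4 (0.07 log units; within the scatter). The estimate for compound 4 is 25000 nM, expected to fall between 8000 nM and 80000 nM.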

Compound 4, half-maximal inhibitory concentration: 25700 nM
Compound 4: middle estimate off by 1.0-fold (0.01 log units), on the low side; the measured number falls inside the stated range.
By their numbers in this assay, from the lowest: compound 2; then compounds 3, 4 and 1 (each within the scatter of the next).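

Moving the chlorine turns 4-chlorophenyl into 3-chlorophenyl, the first change to this group, and in this assay it gives a 1.1-fold lower number from compound 1 to compound 4 (0.06 log units; within the scatter). With the rest of compound 1 unchanged, the chlorine's place on this ring therefore has no effect beyond the scatter. From the compounds shown here alone, whether the same holds when thiophen-2-yl replaces pyridin-3-yl, as in compound 2, remains open. So does the effect of putting an amine or a methoxy group on this ring in place of the chlorine. Nothing available explains why this shift leaves the number so little changed.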